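Lengthening the alkyl chain on an aryl ketone

The source may report more compounds than this note shows. Statements on the series, on what has been measured and on what is new or still open speak of the compounds shown alone.

Three aryl ketones have been measured in an assay on isolated protein for displacement of a labelled ligand from thyroid hormone receptor alpha (Homo sapiens), read by fluorescence polarization; on this read-out higher numbers stand for weaker inhibition and lower numbers for stronger inhibition. Compound 1 `C/C=C/C(=O)c1ccc(CCCCCCC)cc1` gives 18900 nM. For the measured compounds named here, compound 2 `C=C(C)C(=O)c1ccc(CCCCCCC)cc1` gives 52900 nM, and the only measured single-point step, a 2.8-fold higher number from compound 1 to compound 2 (0.45 log units; beyond the scatter), concerns the group on the carbonyl carbon, not the chain. Compound 3 `C=CC(=O)c1ccc(CCCC)cc1` gives 71000 nM, the highest of the three numbers; against compound 2 it lies within the scatter, while against compound 1 it lies beyond it. Compound 4 `C=CC(=O)c1ccc(CCCCCCCC)cc1` differs from compound 3 by butyl in place of hydrogen on a saturated chain carbon, four bonds along the chain from an aromatic carbon. Going by the values given here, no measured step isolates this change. Compounds 1 and 2 carry a longer chain than compound 3 but also a different group on the carbonyl carbon, so their values show only that a longer chain together with that other change gives a lower or similar number. On that basis compound 4 is expected to give 35000 nM, with a range from 10000 nM to 110000 nM. This corresponds to an expected 2.0-fold lower number from compound 3 to compound 4 (0.31 log units; beyond the scatter), a small lowering that may not exceed the scatter.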

Compound 4, half-maximal inhibitory concentration: 21400 nM
The estimate for compound 4 lay 1.6-fold (0.21 log units) above the measured number; the measured number falls inside the stated range.
By their numbers in this assay, from the lowest: compounds 1 and 4 (each within the scatter of the next); then compounds 2 and 3 (each within the scatter of the next).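

In this assay, the chain change now has a step of its own: butyl in place of hydrogen on a saturated chain carbon, four bonds along the chain from an aromatic carbon, gives a 3.3-fold lower number from compound 3 to compound 4 (0.52 log units; beyond the scatter). For the compounds shown here, until now, a longer chain had appeared only together with a different group on the carbonyl carbon, so this is the first reading of chain length alone, and here the longer chain goes with stronger inhibition. Nothing measured here explains why the number falls.

On these data alone, whether the number keeps falling with a still longer chain, such as dodecyl, remains open, as does the effect of a carboxylic acid or an amine at the chain end. Also open, as far as these compounds go, is whether the same lengthening acts alike with prop-1-en-1-yl on the carbonyl carbon.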